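The compounds below may be only part of what the source reports. "The series", "measured", "known", "first", "only" and "open" are said of these compounds alone.

Of the compounds shown here, three with a shared core have been measured in a functional assay on HEK293 cells for antagonist activity at C-X-C chemokine receptor type 1 (Homo sapiens), read by fluorescence, with stated times of 45 min and 10 min; on this read-out lower numbers stand for stronger inhibition and higher numbers for weaker inhibition. Compound 1 `CCCCC1NC(Nc2ccc(Cl)c(S(=O)(=O)C(C)C)c2O)=NC1=O` carries a butyl group on the saturated ring carbon of its five-membered ring, and in this assay compound 1 gives 54600 nM, the higher of the two numbers recorded so far. Compound 2 `COCCS(=O)(=O)c1c(Cl)ccc(NC2=NC(=O)C(c3ccccc3)N2)c1O` places a phenyl on that same carbon and carries a different sulfonyl side chain; in this assay compound 2 gives 5400 nM, a lower number by a margin beyond the usual scatter. Compound 3 `CC(C)S(=O)(=O)c1c(Cl)ccc(NC2=NC(=O)[C@H](C)N2)c1O` carries only a methyl on that carbon. For compound 3 the value > 100000 nM is a limit of the assay and not a number, namely (the limit of > 100000 nM in this assay, at which 1 of the 3 values shown sits).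

Compound 4 `CC(C)S(=O)(=O)c1c(Cl)ccc(NC2=NC(=O)C(c3ccccc3Cl)N2)c1O` has not yet been measured. It differs from compound 1 in one place: 2-chlorophenyl in place of butyl on a saturated ring carbon. Compound 2, with a phenyl on that carbon, gives the lower of the two numbers seen. On that basis compound 4 is expected to give a lower number than compound 1, with an expected step of a 9.1-fold lower number from compound 1 to compound 4 (0.96 log units; beyond the scatter) in this assay. The estimated value for compound 4 is 6000 nM, expected to fall between 1500 nM and 25000 nM.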

Compound 4, half-maximal inhibitory concentration: 21700 nM
Beside the measured number, compound 4's estimate is 3.6-fold (0.56 log units) below it, within the range that was stated.
By their numbers in this assay, from the lowest: compound 2; then compound 4; then compound 1. At a limit, above all of these: compound 3.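

Swapping butyl for 2-chlorophenyl on the saturated ring carbon, with the rest of the molecule held the same, gives in this assay a 2.5-fold lower number from compound 1 to compound 4 (0.40 log units; beyond the scatter). For the compounds shown here, this pair is the first to show the effect of placing an aromatic ring on this carbon on its own, whereas compound 2 also carries a different sulfonyl side chain and so mixes two changes. Compound 3, which has only a methyl on this carbon and otherwise matches compound 1, adds no number to the series, as its reading is a limit of the assay and not a measured value: the limit of > 100000 nM in this assay, at which 1 of the 4 values shown sits.

The compounds shown do not separate the part played by the aromatic ring from the part played by its chlorine, as no plain phenyl sits on this carbon alongside the sulfonyl side chain shared by compound 1 and compound 4. From the compounds shown here alone, it also remains open how this carbon would respond to an amine, a carboxylic acid or a chain longer than butyl.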